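This account rests on a few compounds, and the source may have more. Where it says the series, first, only, none or still open, it means among the compounds named here.

Compound 1 `Cc1ccc(C(=O)/C=C/c2cccc(Br)c2Oc2c([N+](=O)[O-])cc(C(F)(F)F)cc2[N+](=O)[O-])cc1` gives 6.85 ug/mL
Compound 2 `Cc1ccc(C(=O)/C=C/c2cccc(Cl)c2Oc2c([N+](=O)[O-])cc(C(F)(F)F)cc2[N+](=O)[O-])cc1` gives 0.95 ug/mL

Both numbers come from a functional assay on A549 cells (Homo sapiens) for antiproliferative activity, read by MTT assay, with a stated time of 48 h (on this read-out lower numbers stand for stronger inhibition and higher numbers for weaker inhibition), and compound 2 has the lower of the two. The next structure, compound 3 `O=C(/C=C/c1cccc(Cl)c1Oc1c([N+](=O)[O-])cc(C(F)(F)F)cc1[N+](=O)[O-])c1ccc(Cl)cc1`, turns the 4-methylphenyl group into 4-chlorophenyl, with chloro in place of methyl on an aromatic carbon. Among the measured compounds shown here, only one measured step is available as a guide, a 7.2-fold lower number from compound 1 to compound 2 (0.86 log units; beyond the scatter), and it swaps bromo for chloro on a different aromatic carbon. That step shows that one changed atom can move the number in this small set beyond the scatter, which argues for a wide range. It gives no direction for the new change, so no step beyond the scatter is expected. The expected change is a 1.3-fold higher number from compound 2 to compound 3 (0.10 log units; within the scatter), and this is only an estimate. For compound 3 the estimated value is 1.2 ug/mL, with an expected range from 0.4 ug/mL to 4.5 ug/mL.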

Compound 3, half-maximal inhibitory concentration: 11.7 ug/mL
Beside the measured number, compound 3's estimate is 9.8-fold (0.99 log units) below it, outside the stated range (above it).
By their numbers in this assay, from the lowest: compound 2; then compounds 1 and 3 (each within the scatter of the next).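

Going from 4-methylphenyl to 4-chlorophenyl in this assay gives a 12-fold higher number from compound 2 to compound 3 (1.09 log units; beyond the scatter) and so means weaker inhibition. Among the compounds shown here, this is the first evidence that the para position on this ring matters, since the earlier step concerned a different aromatic carbon. Swapping just one heavy atom for another, with no ring, hydrogen-bond donor, acceptor or net charge entering or leaving, is enough to produce a large step here, and nothing measured on these compounds accounts for it.

With only methyl and chloro shown at this position, it remains open whether methyl is unusually favourable or chloro unusually poor. A methoxy group, an amine or a longer chain such as ethyl on the same carbon would help show which, and whether the same step holds with bromo in place of the other chloro is also unknown.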